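The compounds below may be only part of what the source reports. "The series", "measured", "known", "first", "only" and "open" are said of these compounds alone.

Working notes on the series in a functional assay on NTUB1 cells (Homo sapiens) for cytotoxicity, read by MTT assay, with a stated time of 72 h; on this read-out higher numbers stand for weaker inhibition and lower numbers for stronger inhibition: compound 1 `COc1ccc(OC)c(C(=O)/C=C/c2ccc(C(=O)O)cc2)c1` gives 5700 nM, compound 2 `COc1ccc(OC)c(C(=O)/C=C/c2ccc(C(=O)OCc3ccccc3)cc2)c1` gives 13300 nM, and compound 3 `COc1ccc(OC)c(C(=O)/C=C/c2ccc(C(=O)NC(C)C)cc2)c1` gives 1970 nM, the lowest of the three numbers. Compound 4 `CCN(CC)C(=O)c1ccc(/C=C/C(=O)c2cc(OC)ccc2OC)cc1` carries diethylamino in place of isopropylamino on a carbonyl carbon. Among the compounds with values here, no measured step exchanges one amino group for another. The closest evidence comes from changes on the same carbonyl carbon: a 2.9-fold lower number from compound 1 to compound 3 (0.46 log units; beyond the scatter) and a 6.8-fold lower number from compound 2 to compound 3 (0.83 log units; beyond the scatter), both modest. Against that background, no step beyond the scatter is expected in this assay. The estimated step is a 1.5-fold higher number from compound 3 to compound 4 (0.18 log units; within the scatter). For compound 4 the expected value is 3000 nM, with an estimated range of 1200 nM to 7500 nM.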

Compound 4, half-maximal inhibitory concentration: 2690 nM
Compound 4: middle estimate off by 1.1-fold (0.05 log units), on the high side, within the range that was stated.
By their numbers in this assay, from the lowest: compounds 3 and 4 (each within the scatter of the next); then compound 1; then compound 2.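

In this assay, on a carbonyl carbon, diethylamino with no hydrogen-bond donor in place of isopropylamino with one gives a 1.4-fold higher number from compound 3 to compound 4 (0.14 log units; within the scatter), so the amide hydrogen shows no required role at this position. The lower numbers seen with isopropylamino also extend to a second amide, with a 2.1-fold lower number from compound 1 to compound 4 (0.33 log units; beyond the scatter) against the acid and a 4.9-fold lower number from compound 2 to compound 4 (0.69 log units; beyond the scatter) against the benzyl ester. No measurement bears on the reason for these differences. From the compounds shown here alone, whether dimethylamino or the longer dipropylamino on the same carbonyl carbon would stay level with compound 3 and compound 4 remains open.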